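Methyl to ethyl on the thiadiazole side chain

The source may hold more compounds than are shown below. What is called first, only, known or untested is meant among the compounds shown, and "the series" means these compounds.

Of the compounds shown here, two have been read in a functional assay on Huh-7 cells (Homo sapiens) for inhibition, read by MTT assay, with a stated time of 48 h; on this read-out lower numbers stand for stronger inhibition and higher numbers for weaker inhibition. Compound 1 `Cc1nnsc1CO/N=C/c1c(C)nn(C)c1Oc1ccc(Br)cc1` gives 11800 nM in this assay. Compound 2 `Cc1ccc(Oc2c(/C=N/OCc3snnc3C)c(C)nn2C)cc1` carries a methyl in place of the bromo on an aromatic carbon. In this assay compound 2 reaches only the limit > 50000 nM. That is the limit at which compound 2 sits (the limit of > 50000 nM in this assay, at which 1 of the 2 values shown sits). The step of an at least 4.2-fold higher number from compound 1 to compound 2 (0.62 log units; beyond the scatter) is accordingly known only as a lower bound, and compound 2 stands at the weak end of what the series shows, without a number of its own.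

Compound 3 `CCc1nnsc1CO/N=C/c1c(C)nn(C)c1Oc1ccc(C)cc1` differs from compound 2 by methyl in place of hydrogen on a saturated chain carbon bound to an aromatic carbon. Among the measured compounds shown here, the one measured step, bromo to methyl on an aromatic carbon, concerns a different place than the saturated chain carbon bound to an aromatic carbon changed here, so no measured pair bears directly on this change. With compound 2 at the limit and the change limited to one carbon, no step beyond the scatter is expected. The estimated step is a step that the limit leaves unreadable from compound 2 to compound 3. Compound 3 is therefore expected at 60000 nM, with a range of 20000 nM to 200000 nM.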

Compound 3, half-maximal inhibitory concentration: > 50000 nM
Compound 3: only a limit was reported; the forecaster's own chance of this, stated with the estimate: 70%; the middle value is on the limit's open side.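

No step from compound 2 to compound 3 can be read in this assay, because both compounds stand only at a limit of the assay: the limit of > 50000 nM in this assay, at which 2 of the 3 values shown sit.

The compounds shown leave open whether methyl to ethyl on the thiadiazole side chain changes inhibition at all, and how that change would read alongside the bromo of compound 1.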